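The compounds below may be only part of what the source reports. "The series", "measured", "known", "first", "only" and "open" are said of these compounds alone.

Within the data shown here, compound 1 `C=CC(=O)Nc1cccc(Oc2nc(Nc3ccn(C)n3)nc3c2CSCC3)c1` is the only member of the set that gives a number in a functional assay on HeLa cells (Homo sapiens) for antiproliferative activity, read by MTT assay, with a stated time of 72 h; a lower number here means a stronger inhibitor, a higher number a weaker inhibitor: compound 1 gives 25800 nM, a weak inhibitor on that scale. Compound 2 `CC(C)=CC(=O)Nc1cccc(Oc2nc(Nc3ccn(C)n3)nc3c2CSCC3)c1` reaches only a limit of the assay in this assay, reported as > 50000 nM. Compound 3 `C=C(F)C(=O)Nc1cccc(Oc2nc(Nc3ccn(C)n3)nc3c2CSCC3)c1` likewise sits at a limit in this assay, reported as > 50000 nM. The two readable steps, an at least 1.9-fold higher number from compound 1 to compound 2 (0.28 log units; that floor lies within the scatter) and an at least 1.9-fold higher number from compound 1 to compound 3 (0.28 log units; that floor lies within the scatter), both alter the group on the carbonyl carbon and both end at the limit of > 50000 nM in this assay, at which 2 of the 3 values shown sit, so only a floor for their size is known, and that floor lies within the scatter; the step that the two limits leave unreadable from compound 2 to compound 3 cannot be read at all.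

Compound 4 `C=CC(=O)Nc1cccc(Oc2nc(Nc3ccc(OC)cc3)nc3c2CSCC3)c1` leaves the carbonyl end of compound 1 untouched and changes the other arm of the core: 4-methoxyphenyl in place of 1-methyl-1H-pyrazol-3-yl on a nitrogen on an aromatic ring. Among the measured compounds shown here, none of the measured steps touches this nitrogen, so nothing in the set speaks to the direction or size of the change, and compound 1 stands alone as the reference. The expectation for compound 4 is therefore anchored on compound 1, with a wide range in either direction, and the estimated step of a 1.4-fold lower number from compound 1 to compound 4 (0.16 log units; within the scatter) is expected to stay close to no change. In this assay compound 4 is estimated at 18000 nM, between 3000 nM and 50000 nM.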

Compound 4, half-maximal inhibitory concentration: 20900 nM
Beside the measured number, compound 4's estimate is 1.2-fold (0.06 log units) below it, within the range that was stated.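

In this assay, among these compounds, this nitrogen gives the first step in the set whose size can be read, a 1.2-fold lower number from compound 1 to compound 4 (0.09 log units; within the scatter) and the two numbers cannot be told apart. On this nitrogen, then, a six-membered aromatic ring of carbon only carrying a methoxy group stands in place of a five-membered aromatic ring with 2 hetero atoms, and this one exchange of rings leaves the number in the same weak range. Compound 2 and compound 3 remain at a limit of the assay, so the changes on the carbonyl carbon yield only floors, whereas the change on this nitrogen yields a size: the limit of > 50000 nM in this assay, at which 2 of the 4 values shown sit.

From the compounds shown here alone, whether any group on this nitrogen can carry the number beyond the scatter stays open, since one exchange cannot show that the position is insensitive in general, and an unsubstituted phenyl, a pyridine ring or a phenyl bearing a carboxylic acid or an amine would each put that to a further test. Going by these compounds, it also stays open how much of the number depends on the vinyl group on the carbonyl carbon, a question that a saturated ethyl group in its place would address.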